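The compounds below may be only part of what the source reports. "The series", "measured", "known", "first", "only" and "open" are said of these compounds alone.

Measured so far:
- compound 1, `O=C(/C=C\Nc1ccc(Cl)cc1)c1cn(-c2ccccc2)nc1-c1ccc(Cl)cc1`: 13100 nM
- compound 2, `COc1ccc(-c2nn(-c3ccccc3)cc2C(=O)/C=C\Nc2ccc(F)cc2)cc1`: 8910 nM

In a functional assay on U-87MG ATCC cells (Homo sapiens) for antiproliferative activity, read by MTT assay, with a stated time of 48 h (a lower number here means a stronger inhibitor, a higher number a weaker inhibitor), compound 1 gives 13100 nM and compound 2 gives 8910 nM. Compound 2 carries the lower of the two numbers, but the gap to compound 1 lies within the scatter, so the two stand level on the numbers shown. The two structures differ in more than one place, so nothing is read from the pair beyond the two values themselves.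

Compound 3, `COc1ccc(-c2nn(-c3ccccc3)cc2C(=O)/C=C\Nc2ccc(Cl)cc2)cc1`, follows from compound 2 by a single change: chloro in place of fluoro on an aromatic carbon. Within the data shown here, no measured pair in this set isolates such a change. For a swap of one halogen for another at this position, with no change in ring count, donors or acceptors, no step beyond the scatter is expected in this assay; the step from compound 2 to compound 3 is estimated as a 1.0-fold higher number from compound 2 to compound 3 (0.00 log units; within the scatter). Compound 3 is expected to give 9000 nM in this assay, within a range of 4000 nM to 20000 nM.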

Compound 3, half-maximal inhibitory concentration: 8860 nM
Beside the measured number, compound 3's estimate is 1.0-fold (0.01 log units) above it; measured number inside the range.
By their numbers in this assay, from the lowest: compounds 3, 2 and 1 (each within the scatter of the next).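

In this assay, chloro in place of fluoro on the aromatic carbon of the (4-fluorophenyl)amino group gives a 1.0-fold lower number from compound 2 to compound 3 (0.00 log units; within the scatter), so this halogen swap, taken alone, leaves compound 2 and compound 3 level. With the (4-chlorophenyl)amino group held constant, methoxy in place of chloro on an aromatic carbon gives a 1.5-fold lower number from compound 1 to compound 3 (0.17 log units; within the scatter), a single-place reading that compound 1 and compound 2, which differ in more than one place, could not supply. No measured evidence here bears on why either step stays so small.

Fluoro, chloro and methoxy are the only groups shown at these two places, and all three compounds stand level. From the compounds shown here alone, whether an amine or a carboxylic acid at either place would give a step beyond the scatter stays open.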